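The compounds below may be only part of what the source reports. "The series", "measured", "known", "first", "only" and "open" are said of these compounds alone.

Within the data shown here, compound 1 `CC1CC/C(=N\Nc2ccc(Br)cc2)c2ncc(C(=O)O)c(=O)n21` is one of two compounds so far measured in a functional assay on the whole organism for inhibition, with Rattus norvegicus as the target; on this read-out lower numbers stand for an effect already at smaller amounts and higher numbers for an effect only at larger amounts of compound. In this assay compound 1 gives 0.8 umol/kg, the highest of the two numbers. Among the measured compounds shown here, its only neighbour, compound 2 `Cc1cccc(N/N=C2\CCC(C)n3c2ncc(C(=O)O)c3=O)c1`, gives in this assay 0.4 umol/kg, and the step from it to compound 2 amounts to a 2.0-fold lower number from compound 1 to compound 2 (0.30 log units; within the scatter).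

Compound 3 `CC(=O)c1ccc(N/N=C2\CCC(C)n3c2ncc(C(=O)O)c3=O)cc1` is yet to be measured in this assay. It differs from compound 1 in one place: acetyl in place of bromo on an aromatic carbon.

For the measured compounds named here, no measured step concerns an acetyl group or bears directly on this change. The single step available, a 2.0-fold lower number from compound 1 to compound 2 (0.30 log units; within the scatter), replaces the whole substituted phenyl and stays within the scatter, so the shared core carrying a different aryl group has so far shown no shift beyond the scatter. On that basis compound 3 is expected to give a number close to that of compound 1, with a step of about no change at the digits printed from compound 1 to compound 3 (within the scatter) and no direction that can be called beyond the scatter. The estimate for compound 3 in this assay is therefore 0.8 umol/kg, between 0.3 umol/kg and 2.2 umol/kg.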

Compound 3, dose for 50% inhibition: 9.5 umol/kg
Estimate against measurement, compound 3: 12-fold (1.07 log units) below; measured number outside the range, above it.
By their numbers in this assay, from the lowest: compounds 2 and 1 (each within the scatter of the next); then compound 3.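

In this assay the substituent on this aromatic carbon, para to a large group, proves not to be interchangeable: with acetyl in place of bromo there is a large step (a 12-fold higher number from compound 1 to compound 3 (1.07 log units; beyond the scatter)). Among these compounds, the only earlier step (a 2.0-fold lower number from compound 1 to compound 2 (0.30 log units; within the scatter)) exchanged the whole substituted phenyl and stayed within the scatter, so this is the first change on the shared core to move the number beyond it, and it shows that the core does not carry every aryl substituent alike. The change adds heavy atoms, a double bond outside aromatic rings and a hydrogen-bond acceptor, but nothing available ties the higher number to any one of these features.

The compounds shown leave open whether an amine, a carboxylic acid or a nitrile on this same aromatic carbon would give a number close to that of the bromo compound or close to that of the acetyl compound. They also leave open whether the step is particular to acetyl or would recur with a longer acyl chain such as propanoyl, or with acetyl on another carbon of the same ring.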